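This account rests on a few compounds, and the source may have more. Where it says the series, first, only, none or still open, it means among the compounds named here.

Three compounds share one core and differ only in the group on an aromatic carbon of that core. Compound 1 `Cc1cc(NCCN2CCN(C)CC2)nc2ccc(NC(=O)c3ccc(Cl)c(Cl)c3)cc12` carries a (2-(4-methylpiperazin-1-yl)ethyl)amino group, and in a functional assay on SK-BR-3 cells (Homo sapiens) for antiproliferative activity, read by MTT assay, with a stated time of 72 h (a lower number here means a stronger inhibitor, a higher number a weaker inhibitor), compound 1 gives 2690 nM. Compound 2 `Cc1cc(N2CCN(C(C)C)CC2)nc2ccc(NC(=O)c3ccc(Cl)c(Cl)c3)cc12` carries a 4-isopropylpiperazin-1-yl group and in this assay compound 2 gives 6680 nM. Compound 3 `Cc1cc(N2CCN(C)CC2)nc2ccc(NC(=O)c3ccc(Cl)c(Cl)c3)cc12` carries a 4-methylpiperazin-1-yl group and in this assay compound 3 gives 6320 nM, the second highest of the three numbers, sitting within the scatter of compound 2 and with the step of a 2.3-fold higher number from compound 1 to compound 3 (0.37 log units; beyond the scatter) separating it from compound 1.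

Compound 4 `Cc1cc(NCCN2CCCCC2)nc2ccc(NC(=O)c3ccc(Cl)c(Cl)c3)cc12` introduces ((2-(piperidin-1-yl)ethyl)amino in place of 4-methylpiperazin-1-yl on an aromatic carbon). Within the data shown here, two measured steps bear on this. The step of a 2.3-fold higher number from compound 1 to compound 3 (0.37 log units; beyond the scatter) shows that removing the ethylamino link raised the number modestly, so restoring a link should lower it again. The step of a 1.1-fold lower number from compound 2 to compound 3 (0.02 log units; within the scatter) shows that swapping the substituent on the ring nitrogen hardly mattered, so the piperidine in place of methylpiperazine is expected to matter little. In this assay compound 4 is therefore expected to give about 2800 nM, between 1200 nM and 6500 nM, which would mean an estimated step of a 2.3-fold lower number from compound 3 to compound 4 (0.35 log units; beyond the scatter).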

Compound 4, half-maximal inhibitory concentration: 1800 nM
For compound 4 the middle estimate is 1.6-fold (0.19 log units) above the measured one; the range from low to high includes it.
By their numbers in this assay, from the lowest: compounds 4 and 1 (each within the scatter of the next); then compounds 3 and 2 (each within the scatter of the next).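

In this assay, the change to compound 4 gives a 3.5-fold lower number from compound 3 to compound 4 (0.55 log units; beyond the scatter), and the same group in place of 4-isopropylpiperazin-1-yl gives a 3.7-fold lower number from compound 2 to compound 4 (0.57 log units; beyond the scatter), so both compounds with the ring attached directly to the aromatic carbon have higher numbers than compound 4. Among these compounds, what the earlier compounds could not show is whether the end of the chain matters once the ethylamino link is present. With piperidin-1-yl in place of 4-methylpiperazin-1-yl at the chain end, there is a 1.5-fold lower number from compound 1 to compound 4 (0.17 log units; within the scatter), so a second ring nitrogen at that end makes no readable difference in this pair.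

On these data alone, it remains open whether a longer chain between the aromatic carbon and the end ring, or a morpholine or dimethylamino group at the chain end, would keep these numbers or lower them further. Nothing available here explains the differences seen across these compounds.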